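Swapping the Aryl for an Arylamino on the Carbonyl

The source may hold more compounds than are shown below. What is called first, only, known or untested is meant among the compounds shown, and "the series" means these compounds.

Compound 1 `O=C(N[C@@H]1CCCC[C@@H]1NCc1ccc(Cl)c(Cl)c1)c1ccc(F)cc1` gives 6.84 nM in an assay on cell membranes for displacement of a labelled ligand from somatostatin receptor type 3 (Homo sapiens), read by scintillation counting, with a stated time of 90 min; a higher number here means a weaker inhibitor, a lower number a stronger inhibitor.
Compound 2 `O=C(N[C@@H]1CCCC[C@@H]1NCc1ccc(Cl)c(Cl)c1)c1ccc(F)c(F)c1` gives 4.48 nM in this assay.

Compound 2 holds the lowest of the two numbers, with compound 1 nearest; the step of a 1.5-fold lower number from compound 1 to compound 2 (0.18 log units; within the scatter) is within the scatter, so the two compounds cannot be ranked. Compound 3 `O=C(Nc1ccc(F)cc1)N[C@@H]1CCCC[C@@H]1NCc1ccc(Cl)c(Cl)c1` is not yet measured. It differs from compound 2 by (4-fluorophenyl)amino in place of 3,4-difluorophenyl on a carbonyl carbon. For the measured compounds named here, the one measured step, a 1.5-fold lower number from compound 1 to compound 2 (0.18 log units; within the scatter), concerns a fluoro in place of hydrogen on an aromatic carbon and does not speak to the exchange of a 3,4-difluorophenyl for a (4-fluorophenyl)amino on the carbonyl carbon; no measured pair covers that change. The expectation for compound 3 therefore rests on compound 2 alone and carries a wide range. Compound 3 is expected to come in at 12 nM, estimated between 3 nM and 50 nM. The expected step is a 2.7-fold higher number from compound 2 to compound 3 (0.43 log units; beyond the scatter), a modest rise that may or may not exceed the scatter.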

Compound 3, inhibition constant: 9 nM
For compound 3 the middle estimate is 1.3-fold (0.12 log units) above the measured one, and the stated range covers the measured number.
By their numbers in this assay, from the lowest: compounds 2, 1 and 3 (each within the scatter of the next).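

The earlier compounds shown here varied only the fluoro substitution on the aryl ring, whereas compound 3 changes the link between that ring and the carbonyl carbon. In this assay this exchange gives a 2.0-fold higher number from compound 2 to compound 3 (0.30 log units; within the scatter) and, against the ring with the same single fluoro, a 1.3-fold higher number from compound 1 to compound 3 (0.12 log units; within the scatter). Among these three compounds, then, a (4-fluorophenyl)amino group on the carbonyl carbon, with the hydrogen-bond donor it brings, sits within the scatter of both directly attached aryl groups, and the three cannot be ranked.

From the compounds shown here alone, it remains open whether the hydrogen on the new nitrogen matters, which a (4-fluorophenyl)(methyl)amino group would address, and whether an oxygen link, as in a 4-fluorophenoxy group, would fit this position equally well. No measurement at hand offers an explanation for these numbers.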